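Working notes: methoxy to trifluoromethyl and cytotoxicity

The source may hold more compounds than are shown below. What is called first, only, known or untested is meant among the compounds shown, and "the series" means these compounds.

The series is built on the shared core of compound 1 `COc1cc(NC(C)CCCNC(=O)/C(C)=C/c2ccccc2)c2ncccc2c1`, compound 2 `COc1cc(NC(C)CCCNC(=O)NCCCO)c2ncccc2c1` and compound 3 `COc1ccc(/C=C/C(=O)NNC(=O)NCCCC(C)Nc2cc(OC)cc3cccnc23)cc1`. Going by the values given here, in an ADME assay on L6 cells (Rattus norvegicus) for cytotoxicity, read by resazurin assay, with a stated time of 70 h (on this read-out lower numbers stand for stronger inhibition and higher numbers for weaker inhibition), compound 3 gives 3600 nM, the only full number in hand, so it stands alone as the reference point. Compound 1 gives only a limit of the assay, > 250000 nM. That reading is the limit of > 250000 nM in this assay, at which 1 of the 3 values shown sits. For compound 2 the outcome in this assay is "not determined" (no result reported), so no number exists for it. Among the compounds with values here, no two measured compounds differ in a single place, and no measured step can be drawn.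

Compound 4 `COc1cc(NC(C)CCCNC(=O)NNC(=O)/C=C/c2ccc(C(F)(F)F)cc2)c2ncccc2c1` differs from compound 3 by trifluoromethyl in place of methoxy on an aromatic carbon. Within the data shown here, with no measured step to lean on, the expected step in this assay is a 1.2-fold lower number from compound 3 to compound 4 (0.08 log units; within the scatter), a small change not clearly beyond the usual scatter, in either direction. Compound 4 is therefore estimated at 3000 nM in this assay, with a range from 1000 nM to 10000 nM.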

Compound 4, half-maximal inhibitory concentration: 28300 nM
Compound 4: middle estimate off by 9.4-fold (0.97 log units), on the low side, outside the stated range (above it).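

Going by these compounds alone, this is the first measured step: in this assay, trifluoromethyl in place of methoxy on an aromatic carbon, para to a large group, gives a 7.9-fold higher number from compound 3 to compound 4 (0.90 log units; beyond the scatter). The change from 4-methoxyphenyl to 4-(trifluoromethyl)phenyl therefore moves the read-out beyond the usual scatter, towards weaker inhibition, so this position is not indifferent to the group it carries. Nothing in the data shown accounts for the size or direction of this step.

On these data alone, how other groups at this position behave, such as a nitrile, an amine or a carboxylic acid, remains open. Within the data shown here, with only this one pair differing in a single place, it also remains open whether the step would hold on other side chains of the shared core, such as those of compound 1 and compound 2.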